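Dialkylamino chain on a flavone core against prostate cancer cells

A few compounds are considered here, and "the series" means these few. Any claim that something is new, unique, unknown or untested is made for them only; others in the source may bear on it.

The measured compounds are:
compound 1, `CCCCCCOc1c(-c2cc(OC)c(OC)c(OC)c2)oc2ccccc2c1=O`, 29200 nM in a functional assay on PC-3 cells (Homo sapiens) for antiproliferative activity, read by WST assay, with a stated time of 3 days; a lower number here means a stronger inhibitor, a higher number a weaker inhibitor;
compound 2, `CCCN(CCC)CCCCOc1c(-c2cc(OC)c(OC)c(OC)c2)oc2ccccc2c1=O`, 11600 nM;
compound 3, `CCCCN(CCCC)CCCCCOc1c(-c2cc(OC)c(OC)c(OC)c2)oc2ccccc2c1=O`, 6800 nM.

Compound 1 gives the highest number of the three in this assay; the nearest to it is compound 2, the furthest is compound 3. Replacing the ethyl end of its chain with a dipropylamino group gave a 2.5-fold lower number from compound 1 to compound 2 (0.40 log units; beyond the scatter), and the longer dibutylamino counterpart gave a 4.3-fold lower number from compound 1 to compound 3 (0.63 log units; beyond the scatter). Between the two amines themselves the difference was a 1.7-fold lower number from compound 2 to compound 3 (0.23 log units; within the scatter), so the larger amine is not clearly separated from the smaller one.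

The unmeasured compound 4, `CCCCCN(CCCCC)CCCCOc1c(-c2cc(OC)c(OC)c(OC)c2)oc2ccccc2c1=O`, differs from compound 1 by dipentylamino in place of ethyl on a saturated chain carbon, four bonds along the chain from an oxygen on an aromatic ring. Both steps from compound 1 bear on this change, and both were modest but beyond the scatter in the same direction, with the larger amine giving the slightly lower number. Within the data shown here, a comparable modest step to a lower number is therefore expected for compound 4, of about a 4.9-fold lower number from compound 1 to compound 4 (0.69 log units; beyond the scatter), though with only two reference steps the size is uncertain. Compound 4 is estimated at 6000 nM in this assay, within a range of 2500 nM to 14000 nM.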

Compound 4, half-maximal inhibitory concentration: 7900 nM
Compound 4: the middle estimate sits 1.3-fold (0.12 log units) below what was measured; measured number inside the range.
By their numbers in this assay, from the lowest: compounds 3, 4 and 2 (each within the scatter of the next); then compound 1.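

In this assay, dipentylamino at this place, on a saturated chain carbon four bonds along the chain from an oxygen on an aromatic ring, gave a 3.7-fold lower number from compound 1 to compound 4 (0.57 log units; beyond the scatter), so a third dialkylamino compound now stands apart from the amine-free compound 1. Enlarging the amine brought no readable gain, however: the comparisons give a 1.5-fold lower number from compound 2 to compound 4 (0.17 log units; within the scatter) and a 1.2-fold higher number from compound 3 to compound 4 (0.07 log units; within the scatter), both within the scatter, so compound 2, compound 3 and compound 4 show no order by amine size and sit together at one level. Nothing shown here accounts for the gap between these amines and the ethyl end of compound 1.

On these data alone, it remains open whether a much smaller dimethylamino group, a primary amine or a carboxylic acid at the chain end would give a number like those of the three dialkylamino compounds or one closer to that of compound 1. Also open, as far as these compounds go, is what the chain alone contributes, which would take a single amine such as dibutylamino carried on chains of different lengths, with everything else in the molecule kept the same.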